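Working notes: from compound 1 to compound 3

This account rests on a few compounds, and the source may have more. Where it says the series, first, only, none or still open, it means among the compounds named here.

Compound 1 `CCS(=O)(=O)Nc1ccc(Oc2ccc(C#N)cc2)c(-c2cn(C)c(=O)c3[nH]ccc23)c1` measures 11 10^-6 cm/s
Compound 2 `Cn1cc(-c2cc(NS(C)(=O)=O)ccc2Oc2cccnc2)c2cc[nH]c2c1=O` measures 3 10^-6 cm/s

In an ADME assay on MDCK cells (Canis lupus familiaris) for permeability (on this read-out lower numbers stand for lower permeability and higher numbers for higher permeability), compound 1 stands highest of the two measured compounds. Compound 2 lies lower, and that gap is beyond the usual scatter. The two differ in more than one place, so their gap cannot be tied to a single change.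

The next compound to be read out is compound 3 `CCS(=O)(=O)Nc1ccc(OC2CCC(N(C)C)CC2)c(-c2cn(C)c(=O)c3[nH]ccc23)c1`. It keeps the rest of compound 1 and changes one group: 4-(dimethylamino)cyclohexyl in place of 4-cyanophenyl on an oxygen on an aromatic ring. Going by the values given here, no measured pair shows this change on its own, so the expectation for this assay is a judgement from very little data. A moderate fall beyond the scatter is expected, and compound 2 at 3 10^-6 cm/s shows that values in this series can sit well under that of compound 1. The estimated change is a 3.7-fold lower number from compound 1 to compound 3 (0.56 log units; beyond the scatter) in size. For compound 3 the expected value is 3 10^-6 cm/s as an estimate, with a range of 1 10^-6 cm/s to 8 10^-6 cm/s around it.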

Compound 3, apparent permeability: 2.7 10^-6 cm/s
Compound 3: the middle estimate sits 1.1-fold (0.05 log units) above what was measured; the range from low to high includes it.
By their numbers in this assay, from the lowest: compounds 3 and 2 (each within the scatter of the next); then compound 1.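

Going by these compounds alone, this is the first reading of a single change on an oxygen on an aromatic ring: in this assay, 4-(dimethylamino)cyclohexyl in place of 4-cyanophenyl gives a 4.1-fold lower number from compound 1 to compound 3 (0.61 log units; beyond the scatter). With the rest of compound 1 held, the read-out therefore responds to the group on this oxygen, and the response lies beyond the scatter when one six-membered aromatic ring of carbon only and its triple bond give way to one six-membered non-aromatic ring of carbon only bearing dimethylamino. No measurement here explains the size of this step, so it stands as an observation on a single pair.

The pair cannot separate the loss of the aromatic ring from the arrival of the dimethylamino group, as both come in one step; a plain cyclohexyl or a 4-(dimethylamino)phenyl on the same oxygen would divide the two contributions. Also open, from the compounds shown here alone, is whether the step keeps its size on the rest of compound 2, or with a different amine on the cyclohexyl, such as a morpholine or a piperidine.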